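Acetyl enters the pendant phenyl of compound 2

A few compounds are considered here, and "the series" means these few. Any claim that something is new, unique, unknown or untested is made for them only; others in the source may bear on it.

Compound 2 `COc1cc(-n2cnc3ccc(-c4ccccc4)cc32)cc(OC)c1OC` gives 2290 nM in a functional assay on MCF7 cells (Homo sapiens) for antiproliferative activity, read by MTT assay, with a stated time of 72 h (on this read-out lower numbers stand for stronger inhibition and higher numbers for weaker inhibition), the only numerical result among the two values shown. Compound 1 `COc1cc(-n2cnc3ccc(-c4ccccc4Cl)cc32)cc(OC)c1OC` is reported in this assay only as the limit > 10000 nM (the limit of > 10000 nM in this assay, at which 1 of the 2 values shown sits). Going by the values given here, the single measured step, an at least 4.3-fold lower number from compound 1 to compound 2 (0.64 log units; beyond the scatter), concerns chloro on the same ring rather than an acetyl. Compound 3 `COc1cc(-n2cnc3ccc(-c4ccc(C(C)=O)cc4)cc32)cc(OC)c1OC` carries the change (acetyl in place of hydrogen on an aromatic carbon). Among the compounds with values here, no measured step bears directly on this change, so no step beyond the scatter is expected in this assay. Compound 3 is therefore estimated at 2000 nM, between 500 nM and 8000 nM. That estimate means a step of a 1.1-fold lower number from compound 2 to compound 3 (0.06 log units; within the scatter).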

Compound 3, half-maximal inhibitory concentration: 1540 nM
Estimate against measurement, compound 3: 1.3-fold (0.11 log units) above; measured number inside the range.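

In this assay, acetyl on the pendant phenyl gives a 1.5-fold lower number from compound 2 to compound 3 (0.17 log units; within the scatter), so this position, para to a large group, takes the added group without a change beyond the scatter. Set against the 2-chlorophenyl group, the 4-acetylphenyl group gives an at least 6.4-fold lower number from compound 1 to compound 3 (0.81 log units; beyond the scatter), a step that rests on a limit for compound 1 and not on a number: the limit of > 10000 nM in this assay, at which 1 of the 3 values shown sits.

The compounds shown leave open how an amine, a carboxylic acid or a longer chain would read at this place. They also leave open whether acetyl on another carbon of that ring would give the same result.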